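From Sulfamoyl to Piperidinyl: an Unmeasured Step

The source may report more compounds than this note shows. Statements on the series, on what has been measured and on what is new or still open speak of the compounds shown alone.

Compound 1 `Cc1ccc2nc(Nc3nc(Nc4ccc(S(N)(=O)=O)cc4)ncc3C)sc2c1`: in a functional assay on MCF7 cells (Homo sapiens) for antiproliferative activity, read by MTT assay, with a stated time of 48 h (a lower number here means a stronger inhibitor, a higher number a weaker inhibitor), compound 1 gives > 50000 nM, a limit of the assay.
Compound 2 `NS(=O)(=O)c1ccc(Nc2ncc(F)c(Nc3nc4ccccc4s3)n2)cc1`: in this assay compound 2 gives > 50000 nM, a limit of the assay.
Compound 3 `Cc1cnc(Nc2ccc(S(N)(=O)=O)cc2)nc1Nc1nc2ccccc2s1`: in this assay compound 3 gives > 50000 nM, a limit of the assay.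

Compound 3 thus stands at the limit of > 50000 nM in this assay, at which 3 of the 3 values shown sit, and no number places it against the other two. Compound 4 `Cc1cnc(Nc2ccc(N3CCCCC3)cc2)nc1Nc1nc2ccccc2s1` differs from compound 3 by piperidin-1-yl in place of sulfamoyl on an aromatic carbon. Among the compounds with values here, the steps measured so far, a step that the two limits leave unreadable from compound 1 to compound 3 and a step that the two limits leave unreadable from compound 2 to compound 3, touch other places and are unreadable in size, so they give no direction for this change, and no measured step swaps the sulfamoyl. The size of the step in this assay is therefore open. Compound 4 is expected at 30000 nM, between 3000 nM and 100000 nM, an estimated at least 1.6-fold lower number from compound 3 to compound 4 (0.22 log units; that floor lies within the scatter), with a fair chance that only a limit is again reported.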

Compound 4, half-maximal inhibitory concentration: > 50000 nM
Compound 4 ended at the assay's limit (the forecaster's own chance of this, stated with the estimate: 55%); at least 1.6-fold (0.22 log units) between middle value and limit.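

In this assay, within the data shown here, compound 3 and compound 4 both end at a limit, so no step between them can be read. Open is whether any change to these compounds gives a measurable number, as every value shown is a limit: the limit of > 50000 nM in this assay, at which 4 of the 4 values shown sit.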